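Carboxylic Chain Shape and Platelet Inhibition

This account rests on a few compounds, and the source may have more. Where it says the series, first, only, none or still open, it means among the compounds named here.

Compound 1 `CC(CC(=O)O)N1Cc2ccc(NC(=O)CCCC3CCNCC3)cc2C1=O` and compound 2 `CC(CC(=O)O)N1Cc2ccc(NC(=O)c3ccc(C4CCNCC4)cc3)cc2C1=O` share much of their structure, but the difference between the two cores is not broken down here. In a functional assay on a cell-free system (Platelet, plasma, Homo sapiens) for inhibition (a lower number here means a stronger inhibitor, a higher number a weaker inhibitor), compound 1 gives 5400 nM, and compound 2 gives 6200 nM, two numbers that lie within the usual scatter of each other. Compound 3 `O=C(O)CCCN1Cc2ccc(NC(=O)CCCC3CCNCC3)cc2C1=O` arises from compound 1 through (3-carboxypropyl in place of 1-(carboxymethyl)ethyl on an amide-type nitrogen in a ring), and in this assay compound 3 gives 51000 nM, a weakening step of a 9.4-fold higher number from compound 1 to compound 3 (0.98 log units; beyond the scatter). Compound 4 `O=C(O)CCCN1Cc2ccc(NC(=O)c3ccc(C4CCNCC4)cc3)cc2C1=O` has not yet been measured; it arises from compound 2 through the same change at the same place, (3-carboxypropyl in place of 1-(carboxymethyl)ethyl on an amide-type nitrogen in a ring). Among the measured compounds shown here, because the one measured instance of this change gave a 9.4-fold higher number from compound 1 to compound 3 (0.98 log units; beyond the scatter), a step of about the same size is expected, an 8.1-fold higher number from compound 2 to compound 4 (0.91 log units; beyond the scatter). On that basis compound 4 is estimated at 50000 nM, with a likely range from 15000 nM to 150000 nM in this assay.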

Compound 4, half-maximal inhibitory concentration: 410000 nM
Compound 4: middle estimate off by 8.2-fold (0.91 log units), on the low side; the whole stated range lies below it.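

Putting 3-carboxypropyl in place of 1-(carboxymethyl)ethyl gives a weaker inhibitor on both cores in this assay, and on the core of compound 2 the step is a 66-fold higher number from compound 2 to compound 4 (1.82 log units; beyond the scatter). The direction carried from one core to the other, but the size did not: the same change on two cores in this assay, a 9.4-fold higher number (0.98 log units; beyond the scatter) from compound 1 to compound 3 and a 66-fold higher number (1.82 log units; beyond the scatter) from compound 2 to compound 4, 7.0-fold (0.85 log units) apart, beyond the scatter of two such steps. Among the compounds shown here, with only two pairs, this suggests that a step measured on one core can guide direction, but it shows neither why the sizes differ nor what a further core would do.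

The compounds shown leave open how a shorter or longer chain ending in a carboxylic acid would behave on the amide-type nitrogen in a ring. They also leave open whether an ester in place of the carboxylic acid would change the size of the step on either core.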